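This account rests on a few compounds, and the source may have more. Where it says the series, first, only, none or still open, it means among the compounds named here.

Measured so far: compound 1 `COc1cc(-c2cc(/C=C/C(=O)c3ccc(N)cc3)[nH]n2)cc(OC)c1OC` gives -19% in a functional assay on 786-0 cells (Homo sapiens) for cytotoxicity, read by sulforhodamine B assay, with a stated time of 48 h, tested at 10 uM; a lower number here means a stronger effect, a higher number a weaker effect of the compound at the concentration tested; compound 2 `COc1ccc(-c2cc(/C=C/C(=O)c3ccc(N)cc3)[nH]n2)cc1OC` gives -48%; compound 3 `COc1cc(C(=O)/C=C/c2cc(-c3cc(OC)c(OC)c(OC)c3)n[nH]2)cc(OC)c1OC` gives -77%.

Between compound 1 and compound 2 the change is hydrogen in place of methoxy on an aromatic carbon, and it made a step of a number 29 percentage points lower from compound 1 to compound 2 (beyond the scatter). Compound 3 lies lowest of the three, and how its core differs from that of compound 1 is not broken down here. Compound 4 `COc1ccc(-c2cc(/C=C/C(=O)c3cc(OC)c(OC)c(OC)c3)[nH]n2)cc1OC` is not yet measured; it arises from compound 3 by hydrogen in place of methoxy on an aromatic carbon, the same change at the same kind of place. Because compound 2 sits at -48% after that change from compound 1, a step of similar size is expected from compound 3 to compound 4 in this assay, namely a number 13 percentage points lower from compound 3 to compound 4 (beyond the scatter). Compound 4 is therefore estimated at -90%, between -105% and -65%.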

Compound 4, a percentage reported as activity, at one concentration (the size of the read-out at that concentration, not a potency): -94%
For compound 4 the middle estimate is 4 percentage points above the measured one; the measured number falls inside the stated range.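

Putting hydrogen in place of one methoxy moved the read-out in the same direction on both cores in this assay, with a number 17 percentage points lower from compound 3 to compound 4 (beyond the scatter). The sizes of the two steps cannot be told apart: the same change on two cores in this assay, a number 29 percentage points lower (beyond the scatter) from compound 1 to compound 2 and a number 17 percentage points lower (beyond the scatter) from compound 3 to compound 4, 12 percentage points apart, within the scatter of two such steps. So, for these two pairs, the change carried from one core to the other in direction and in approximate size, but two pairs cannot establish a rule for other cores or explain why the number falls.

The compounds shown have only methoxy or hydrogen at this place on the ring. As far as these compounds go, how a chlorine, a hydroxyl group or a longer ether such as ethoxy would behave there remains open.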